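This account rests on a few compounds, and the source may have more. Where it says the series, first, only, none or still open, it means among the compounds named here.

Of the compounds shown here, three have so far been measured in an assay on isolated protein with adenosine receptor A1 (Homo sapiens) as the target, tested at 10 uM; on this read-out higher numbers stand for more inhibition at the one concentration tested (going by the name of the read-out) and lower numbers for less inhibition. Compound 1 `Cc1sc(N)c(C(=O)c2cccc3ccccc23)c1C` gives 0%, compound 2 `Nc1sc2c(c1C(=O)c1cccc3ccccc13)CCC2` gives 8%, and compound 3 `COc1ccc(C(=O)c2c(N)sc3c2CCC3)c2ccccc12` gives 19%, the highest of the three numbers and beyond the scatter from both others. Within the data shown here, the only measured single change is a number 11 percentage points higher from compound 2 to compound 3 (beyond the scatter). Compound 4 `Nc1sc2c(c1C(=O)c1ccc(Cl)c3ccccc13)CCC2` differs from compound 3 by chloro in place of methoxy on an aromatic carbon. Among the measured compounds shown here, no measured step exchanges one group for another at this position, so the earlier methoxy-for-hydrogen step gives only an indirect guide: the methoxy brought a modest gain, and whether chloro keeps that gain is unknown. A small downward shift, or none beyond the scatter, is therefore expected, a number 4 percentage points lower from compound 3 to compound 4 (within the scatter). Compound 4 is estimated at 15%, between 0% and 35%.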

Compound 4, a percentage reported as inhibition, at one concentration (the size of the read-out at that concentration, not a potency): 0%
Beside the measured number, compound 4's estimate is 15 percentage points above it; low and high end bracket the measured number.
By their numbers in this assay, from the lowest: compounds 1, 4 and 2 (each within the scatter of the next); then compound 3.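

In this assay, the gain seen with methoxy does not carry over to chloro on this aromatic carbon: the exchange gives a number 19 percentage points lower from compound 3 to compound 4 (beyond the scatter) on the same core. Set against hydrogen, chloro gives a number 8 percentage points lower from compound 2 to compound 4 (within the scatter) and so brings no gain beyond the scatter, which leaves methoxy as the only group shown here to stand apart from hydrogen. Nothing available explains why methoxy and chloro differ. Still open, on these data alone, is whether ethoxy, a hydroxyl or an amine at this place would match methoxy.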